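This account rests on a few compounds, and the source may have more. Where it says the series, first, only, none or still open, it means among the compounds named here.

Three analogues that share a common core have been examined in an ADME assay on cells (Hepatocyte, Rattus norvegicus) for metabolic stability, using equilibrium dialysis; a higher number here means faster removal of the compound, a lower number slower removal. Compound 1 `CC(=O)N[C@@H]1CCC[C@H](C(=O)Nc2cc(-c3cnc4n3CCC4)c(Cl)cn2)C1` gives 19 uL/min in this assay. Compound 2 `CC(=O)N[C@@H]1CCC[C@H](C(=O)Nc2cc(-c3cnn4c3COCC4)c(Cl)cn2)C1` gives 18 uL/min, and the step from compound 1 to compound 2 is a 1.1-fold lower number from compound 1 to compound 2 (0.02 log units; within the scatter). Compound 3 `CC(=O)N[C@@H]1CCC[C@H](C(=O)Nc2cc(-c3cnn4c3CN(C)CC4)c(Cl)cn2)C1` gives 7.7 uL/min, which is the lowest of the three numbers; the step from compound 1 to compound 3 is a 2.5-fold lower number from compound 1 to compound 3 (0.39 log units; beyond the scatter), and that from compound 2 to compound 3 is a 2.3-fold lower number from compound 2 to compound 3 (0.37 log units; beyond the scatter).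

Compound 4 `CC(=O)N[C@@H]1CCC[C@H](C(=O)Nc2cc(-c3cnn4c3CC(C)(C)C4)c(Cl)cn2)C1` differs from compound 3 in one place: a group of 10 heavy atoms (8 carbon, 2 nitrogen; one five-membered non-aromatic ring with 1 hetero atom, one five-membered aromatic ring with 2 hetero atoms) in place of a group of 10 heavy atoms (7 carbon, 3 nitrogen; one five-membered aromatic ring with 2 hetero atoms, one six-membered non-aromatic ring with 2 hetero atoms), on an aromatic carbon. The group that enters resembles in its ring make-up the group carried by compound 1, with two extra carbon atoms on the five-membered non-aromatic ring. The step from compound 1 to compound 3 a 2.5-fold lower number from compound 1 to compound 3 (0.39 log units; beyond the scatter) is the closest guide, and reversing a change of that kind would be expected to raise the number by a modest amount, so the step from compound 3 to compound 4 is estimated at a 2.2-fold higher number from compound 3 to compound 4 (0.34 log units; beyond the scatter). Compound 4 is therefore expected to give about 17 uL/min in this assay, with a likely range of 8 uL/min to 35 uL/min.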

Compound 4, intrinsic clearance in a liver preparation (reported as CLH), per the amount of preparation that the assay uses: 73 uL/min
For compound 4 the middle estimate is 4.3-fold (0.63 log units) below the measured one, outside the stated range (above it).
By their numbers in this assay, from the lowest: compound 3; then compounds 2 and 1 (each within the scatter of the next); then compound 4.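

In this assay, within the data shown here, this position proves far more sensitive than the earlier compounds suggested: the new group gives a 9.5-fold higher number from compound 3 to compound 4 (0.98 log units; beyond the scatter) and also a 4.1-fold higher number from compound 2 to compound 4 (0.61 log units; beyond the scatter) in the same direction. Compound 4 thus stands alone at the top of the series, beyond the scatter of all three earlier compounds. Ring make-up alone does not set the number, since the groups of compound 1 and compound 4 share it and there is still a 3.8-fold higher number from compound 1 to compound 4 (0.58 log units; beyond the scatter) on going to the larger group. Nothing available here accounts for this rise. Going by these compounds, whether a hydroxyl group or fluorine atoms in place of the extra carbon atoms on the five-membered non-aromatic ring would bring the number back towards that of compound 1 remains open. So does whether an ethyl or acetyl group on the ring nitrogen of compound 3 would hold its low number.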